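The source may hold more compounds than are shown below. What is called first, only, known or untested is meant among the compounds shown, and "the series" means these compounds.

The series shares the core of compound 1 `Cc1cn(C2CCN(Cc3cccc(OC4CCCCC4)c3)CC2)c(=O)[nH]c1=O`, and the group on the oxygen on the aromatic ring is what varies. In an ADME assay on MRC5 cells (Homo sapiens) for cytotoxicity, read by fluorescence and resazurin assay, with a stated time of 3 days (a lower number here means a stronger inhibitor, a higher number a weaker inhibitor), compound 1 gives 23600 nM. Compound 2 `Cc1cn(C2CCN(Cc3cccc(Oc4cccc(F)c4)c3)CC2)c(=O)[nH]c1=O` carries 3-fluorophenyl there; in this assay compound 2 reaches only > 64000 nM, which is a limit of the assay and not a number. Compound 3 `COc1cccc(Oc2cccc(CN3CCC(n4cc(C)c(=O)[nH]c4=O)CC3)c2)c1` carries 3-methoxyphenyl; in this assay compound 3 gives 25300 nM. Of the two numbers, compound 3 stands highest, with compound 1 nearest: a 1.1-fold higher number from compound 1 to compound 3 (0.03 log units; within the scatter). The remaining steps are an at least 2.7-fold higher number from compound 1 to compound 2 (0.43 log units; beyond the scatter) and an at least 2.5-fold lower number from compound 2 to compound 3 (0.40 log units; beyond the scatter).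

Compound 4 `Cc1cn(C2CCN(Cc3cccc(OC4CCCC4)c3)CC2)c(=O)[nH]c1=O` is not yet measured. It differs from compound 3 as follows: cyclopentyl in place of 3-methoxyphenyl on an oxygen on an aromatic ring. Among the compounds with values here, the measured step that bears on this is the exchange of cyclohexyl for 3-methoxyphenyl, a 1.1-fold higher number from compound 1 to compound 3 (0.03 log units; within the scatter), which lay within the scatter; cyclopentyl itself has not been measured, and no step separates cyclopentyl from cyclohexyl. A non-aromatic ring in place of the aromatic one is therefore expected to give no step beyond the scatter in this assay. The step expected is a 1.2-fold lower number from compound 3 to compound 4 (0.06 log units; within the scatter). For compound 4 in this assay the estimate is 22000 nM, between 9000 nM and 55000 nM.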

Compound 4, half-maximal inhibitory concentration: 30300 nM
Compound 4: middle estimate off by 1.4-fold (0.14 log units), on the low side; measured number inside the range.
By their numbers in this assay, from the lowest: compounds 1, 3 and 4 (each within the scatter of the next). At a limit, above all of these: compound 2.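

In this assay, the step for cyclopentyl on an oxygen on an aromatic ring is a 1.2-fold higher number from compound 3 to compound 4 (0.08 log units; within the scatter), and against the larger non-aromatic ring it is a 1.3-fold higher number from compound 1 to compound 4 (0.11 log units; within the scatter); a five-membered non-aromatic ring, a six-membered non-aromatic ring and 3-methoxyphenyl at this position thus give values that cannot be told apart. Compound 2 goes against any reading of this position as indifferent to the group, with an at least 2.1-fold lower number from compound 2 to compound 4 (0.32 log units; beyond the scatter), so 3-fluorophenyl now stands apart from both non-aromatic rings as well as from 3-methoxyphenyl. Compound 2 remains the only compound at a limit of the assay, which is not a number: the limit of > 64000 nM in this assay, at which 1 of the 4 values shown sits.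

The compounds shown leave open whether an open chain such as n-butyl, or an aromatic ring carrying an amine or a carboxylic acid, on this oxygen would stay with compounds 1, 3 and 4 in this assay. As far as these compounds go, how far compound 2 lies from the other three also stays open, its entry being only a limit.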